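From Compound 3 to Compound 4: An Expected Drop

The source may report more compounds than this note shows. Statements on the series, on what has been measured and on what is new or still open speak of the compounds shown alone.

Of the compounds shown here, three have so far been tested in a functional assay on the whole organism with Rattus norvegicus as the target, at a dose of 100 mg/kg; on this read-out higher numbers stand for more inhibition at the one dose given (going by the name of the read-out) and lower numbers for less inhibition. Compound 1 `N#CNC(=N)NCCCCCn1nc(-c2ccccc2)ccc1=O` gives 31%, compound 2 `C/N=C(\S)NCCCCCn1nc(-c2ccccc2)ccc1=O` gives 68.9%, and compound 3 `CC/N=C(\S)NCCCCCn1nc(-c2ccccc2)ccc1=O` gives 66.4%, the second highest of the three; the nearest step is a number 2.5 percentage points lower from compound 2 to compound 3 (within the scatter) and the furthest is a number 35.4 percentage points higher from compound 1 to compound 3 (beyond the scatter).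

Compound 4 `C/N=C(/NC#N)NCCCCCCn1nc(-c2ccccc2)ccc1=O` differs from compound 3 as follows: a group of 8 heavy atoms (4 carbon, 4 nitrogen; no ring) in place of a group of 6 heavy atoms (3 carbon, 2 nitrogen, 1 sulfur; no ring), on a saturated chain carbon, five bonds along the chain from an aromatic nitrogen. Among the measured compounds shown here, the entering group of compound 4 resembles the group carried by compound 1, so the steps that bear on this change are a number 37.9 percentage points higher from compound 1 to compound 2 (beyond the scatter) and a number 35.4 percentage points higher from compound 1 to compound 3 (beyond the scatter), both large. Run in reverse, compound 4 is expected to fall well below compound 3, with a number 31.4 percentage points lower from compound 3 to compound 4 (beyond the scatter) expected to lie beyond the scatter. In this assay compound 4 is estimated at 35%, within 15% to 58%.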

Compound 4, a percentage reported as inhibition, in the whole organism at one dose (the size of the read-out at that dose, not a potency): 31.7%
Compound 4: the middle estimate sits 3.3 percentage points above what was measured, within the range that was stated.
By their numbers in this assay, from the lowest: compounds 1 and 4 (each within the scatter of the next); then compounds 3 and 2 (each within the scatter of the next).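

In this assay, the group entering on a saturated chain carbon, five bonds along the chain from an aromatic nitrogen, goes with large falls against both sulfur-bearing partners: a number 34.7 percentage points lower from compound 3 to compound 4 (beyond the scatter) and a number 37.2 percentage points lower from compound 2 to compound 4 (beyond the scatter). Against compound 1, whose group holds only carbon and nitrogen, the change gives a number 0.7 percentage points higher from compound 1 to compound 4 (within the scatter). Thus compound 2 and compound 3 stand apart from compound 1 and compound 4, and no compound shown goes against this split.

Nothing on hand gives a cause for these steps. The compounds shown leave open how an amine or a carboxylic acid at this place would read in this assay.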